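Ring Size Beside the Sulfonyl: Cyclobutyl to Cyclohexyl

The source may report more compounds than this note shows. Statements on the series, on what has been measured and on what is new or still open speak of the compounds shown alone.

Of the compounds shown here, three have been measured in a functional assay, read by fluorescence and spectrophotometry, with a stated time of 1 h; a higher number here means that more compound is needed for the effect, a lower number that less compound is needed. Compound 1 `CCCCCCCCCCCCS(=O)(=O)/C=C/c1ccc(O)c(O)c1` gives 8500 nM, compound 2 `C=CCCCCCCCS(=O)(=O)/C=C/c1ccc(O)c(O)c1` gives 6900 nM, and compound 3 `O=S(=O)(/C=C/c1ccc(O)c(O)c1)CC1CCC1` gives 8800 nM. The three numbers sit close together: compound 3 is nominally the highest of them, yet its gaps to compound 1 and to compound 2 both lie within the scatter of this assay, so no ordering among the three can be claimed. For the measured compounds named here, the only single-change step on record, a 1.2-fold lower number from compound 1 to compound 2 (0.09 log units; within the scatter), concerns a distant part of the chain and is itself within the scatter.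

Compound 4 `O=S(=O)(/C=C/c1ccc(O)c(O)c1)CC1CCCCC1` is not yet measured. It differs from compound 3 in one place: cyclohexyl in place of cyclobutyl on a saturated chain carbon bound to a sulfonyl sulfur. Going by the values given here, no measured pair shows this particular exchange, so the step from compound 1 to compound 2 is the only guide, and it speaks for a flat response to changes on the chain carried by the sulfonyl. The step from compound 3 to compound 4 is therefore expected to be a 1.1-fold lower number from compound 3 to compound 4 (0.04 log units; within the scatter), with no direction beyond the scatter. Compound 4 is estimated to give 8000 nM in this assay, within a range from 3500 nM to 18000 nM.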

Compound 4, half-maximal effective concentration: 7500 nM
The estimate for compound 4 lay 1.1-fold (0.03 log units) above the measured number; the range from low to high includes it.
By their numbers in this assay, from the lowest: compounds 2, 4, 1 and 3 (each within the scatter of the next).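

In this assay, cyclohexyl in place of cyclobutyl on a saturated chain carbon bound to a sulfonyl sulfur gives a 1.2-fold lower number from compound 3 to compound 4 (0.07 log units; within the scatter). For the compounds shown here, this is the first single-change step read at this position, as the earlier step lay seven bonds along the chain from a sulfonyl sulfur, and it shows that a four-membered and a six-membered non-aromatic ring of carbon only, with 4 and 6 heavy atoms, cannot be told apart here by this read-out. The result therefore describes a size change among carbon-only rings at this position and offers no reason for the small step, and no supporting measurement is available to explain it.

From the compounds shown here alone, both rings have no hydrogen-bond donors or acceptors, so it remains open whether an amine, a carboxylic acid or a phenyl ring at this same place would also leave the number within the scatter. It also remains open how the number would respond to a change on the shared core, which is the same in all the compounds shown.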